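Alkoxy variation on the dimethylphenyl ring of the series

The compounds below may be only part of what the source reports. "The series", "measured", "known", "first", "only" and "open" are said of these compounds alone.

The shared core is shown by compound 1 `Cc1cc(O)cc(C)c1-c1cccc(COc2ccc(OCC(=O)O)c(F)c2)c1`, which carries a hydroxyl on the dimethyl-substituted ring. In a functional assay on CHO cells for agonist activity at Free fatty acid receptor 1 (Homo sapiens), read by FLIPR and calcium flux (on this read-out lower numbers stand for an effect already at smaller amounts and higher numbers for an effect only at larger amounts of compound), compound 1 gives 110 nM. Compound 2 `Cc1cc(OCC(=O)N(C)C)cc(C)c1-c1cccc(COc2ccc(OCC(=O)O)c(F)c2)c1` replaces that hydroxyl with a (dimethylcarbamoyl)methoxy group; for compound 2 the result in this assay is "not determined" (no result reported), so it stands on no number and cannot be placed against compound 1. Compound 3 `Cc1cc(OCCCO)cc(C)c1-c1cccc(COc2ccc(OCC(=O)O)c(F)c2)c1` has not been measured. The change from compound 2 to compound 3 is 2-hydroxyethyl in place of dimethylcarbamoyl on a saturated chain carbon bound to an oxygen on an aromatic ring. Within the data shown here, with no measured pair on either side of this change, the size of the step in this assay cannot be read from the data; the only anchor is compound 1 with 110 nM, and a step of ordinary size in either direction, or none beyond the scatter, is equally open. Compound 3 is therefore expected to lie near the value of compound 1, with an estimate of 80 nM and a plausible range from 20 nM to 300 nM.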

Compound 3, half-maximal effective concentration: 110 nM
For compound 3 the middle estimate is 1.4-fold (0.14 log units) below the measured one; the range from low to high includes it.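

In this assay there is no change at the digits printed from compound 1 to compound 3 (within the scatter), with 3-hydroxypropyl in place of hydrogen on an oxygen on an aromatic ring. This gives the series its first readable comparison at this place: the free hydroxyl of compound 1 can be capped with this chain without a change beyond the scatter, which compound 1 alone could not show, and compound 2 gave no number to show it. This holds for this one chain only, and no measurement at hand gives a reason for the result.

Going by these compounds, the steps that involve compound 2 cannot be read, so the standing of the (dimethylcarbamoyl)methoxy group against the 3-hydroxypropoxy group stays open, and with it whether the terminal hydroxyl of compound 3 plays any part in the read-out. Also open, on these data alone, is whether the same level holds when the chain ends in an amine or a carboxylic acid, when it is a plain propyl chain with no hydroxyl, or when a longer chain sits on the same oxygen.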